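Urea to amide on the shared core: compound 3

The compounds below may be only part of what the source reports. "The series", "measured", "known", "first", "only" and "open" are said of these compounds alone.

Measured so far in a functional assay on SF-539 cells (Homo sapiens) for inhibition, read by sulforhodamine B assay, with a stated time of 48 h; a lower number here means a stronger inhibitor of growth, a higher number a weaker inhibitor of growth:
compound 1 `COc1cc(-c2nn(-c3cccc(NC(=O)Nc4ccc(Cl)c(Cl)c4)c3)cc2-c2ccncc2)ccc1Cl`, 3080 nM
compound 2 `COc1cc(-c2nn(-c3cccc(NC(=O)Nc4cccc(C(F)(F)F)c4)c3)cc2-c2ccncc2)ccc1Cl`, 2420 nM

Compound 2 and compound 1 sit within the scatter of each other, the step being a 1.3-fold lower number from compound 1 to compound 2 (0.10 log units; within the scatter). Compound 3 `COc1cc(-c2nn(-c3cccc(NC(=O)c4ccc(Cl)c(C(F)(F)F)c4)c3)cc2-c2ccncc2)ccc1Cl` differs from compound 2 by 4-chloro-3-(trifluoromethyl)phenyl in place of (3-(trifluoromethyl)phenyl)amino on a carbonyl carbon. Among the compounds with values here, the one measured step, from compound 1 to compound 2, only swapped the aryl on the urea nitrogen and stayed within the scatter; no measured step removes the amino link itself, so that part is unsupported. Expectation for compound 3 is therefore no change beyond the scatter, a 1.2-fold higher number from compound 2 to compound 3 (0.09 log units; within the scatter), giving an estimate of 3000 nM with a range of 1000 nM to 9000 nM.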

Compound 3, concentration for total growth inhibition: 20300 nM
Beside the measured number, compound 3's estimate is 6.8-fold (0.83 log units) below it; measured number above the stated range.
By their numbers in this assay, from the lowest: compounds 2 and 1 (each within the scatter of the next); then compound 3.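

In this assay the carbonyl carbon's substituent matters: 4-chloro-3-(trifluoromethyl)phenyl in place of (3-(trifluoromethyl)phenyl)amino gives an 8.4-fold higher number from compound 2 to compound 3 (0.92 log units; beyond the scatter) and in place of (3,4-dichlorophenyl)amino gives a 6.6-fold higher number from compound 1 to compound 3 (0.82 log units; beyond the scatter) in the same direction, whereas the earlier aryl swap on the urea stayed within the scatter. Both steps remove the amino link with its hydrogen-bond donor. Nothing available explains the rise.

Whether the lost amino link or the added chlorine carries the step remains unresolved. A methylene link in place of the amino nitrogen could help separate the two.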